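A few compounds are considered here, and "the series" means these few. Any claim that something is new, unique, unknown or untested is made for them only; others in the source may bear on it.

Of the compounds shown here, two with a shared core have been measured so far. In a functional assay on HGC-27 cells (Homo sapiens) for inhibition, read by MTT assay, with a stated time of 72 h (on this read-out lower numbers stand for stronger inhibition and higher numbers for weaker inhibition), compound 1 `Cc1ccc(N2CCCC2)c(C(=O)Nc2ccc(CNC(=O)OCc3cccnc3)cc2)c1` gives 1650 nM and compound 2 `Cc1ccc(C(=O)Nc2ccc(CNC(=O)OCc3cccnc3)cc2)c(N2CCCC2)c1` gives 1870 nM. These two values lie within the scatter of repeated measurements, so this read-out cannot tell compound 1 apart from compound 2.

Compound 3 `O=C(NCc1ccc(NC(=O)c2cc(Br)ccc2N2CCCC2)cc1)OCc1cccnc1` has not yet been measured, and it differs from compound 1 in one place: bromo in place of methyl on an aromatic carbon. The rest of the structure stays the same. Among the compounds with values here, no measured pair in this small set shows what such a swap does, and that leaves both the size and the direction of any change open.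

The best starting point is the value of compound 1, 1650 nM. No step beyond the scatter is expected in this assay. The estimated change is a 1.2-fold lower number from compound 1 to compound 3 (0.07 log units; within the scatter). For compound 3, the expected value is 1400 nM, with an estimated range from 600 nM to 3300 nM.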

Compound 3, half-maximal inhibitory concentration: 640 nM
Estimate against measurement, compound 3: 2.2-fold (0.34 log units) above, within the range that was stated.
By their numbers in this assay, from the lowest: compound 3; then compounds 1 and 2 (each within the scatter of the next).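

In this assay, the aromatic carbon para to a pyrrolidin-1-yl group and meta to a large group responds to what it carries: putting bromo in place of methyl there gives a 2.6-fold lower number from compound 1 to compound 3 (0.41 log units; beyond the scatter), a modest step but one beyond the scatter. Within the data shown here, compounds 1 and 2 alone showed no step at all, so this is the first sign in the set that a change at a single place can shift this read-out, and it takes only one heavy atom exchanged for another, with no change in the counts of hydrogen-bond donors, hydrogen-bond acceptors or net charge. Nothing given here explains why the number falls with this swap.

Among these compounds, a single pair shows only one swap at one position, so it remains open whether chloro, methoxy or an amine on the same carbon would move the number in the same direction, or by a similar amount. Going by these compounds, it also remains open whether bromo in place of methyl on the core of compound 2 would give a similar step.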